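Working notes: halogen exchange in a small antiproliferative series

The source may hold more compounds than are shown below. What is called first, only, known or untested is meant among the compounds shown, and "the series" means these compounds.

Measured compounds:
compound 1, `Fc1ccc(-c2nn(-c3ccccc3)cc2-c2nc3ccccc3[nH]2)cc1`, 1510 nM
compound 2, `Clc1ccc(-c2nn(-c3ccccc3)cc2-c2nc3ccccc3[nH]2)cc1`, 5960 nM
compound 3, `Fc1ccc2[nH]c(-c3cn(-c4ccccc4)nc3-c3ccc(Cl)cc3)nc2c1`, 4610 nM

All three numbers come from a functional assay on A549 cells (Homo sapiens) for antiproliferative activity, read by MTT assay, with a stated time of 48 h; on this read-out higher numbers stand for weaker inhibition and lower numbers for stronger inhibition. Within the set, compound 1 gives the lowest number. The change chloro in place of fluoro on an aromatic carbon produces a 3.9-fold higher number from compound 1 to compound 2 (0.60 log units; beyond the scatter), a step that stands beyond the scatter. The further change from compound 2 to compound 3, fluoro in place of hydrogen on an aromatic carbon, gives a 1.3-fold lower number from compound 2 to compound 3 (0.11 log units; within the scatter), which is within the scatter, so compound 2 and compound 3 cannot be ordered against each other. Compound 3 and compound 1 differ in more than one place; the difference between the two cores is not broken down here, and the two values simply show compound 3 with the higher number.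

Compound 4, `Clc1ccc(-c2nn(-c3ccccc3)cc2-c2nc3cc(Cl)ccc3[nH]2)cc1`, is not yet measured. It differs from compound 3 by chloro in place of fluoro on an aromatic carbon. Among the compounds with values here, this is the same kind of change as the one from compound 1 to compound 2, but not the same: in compound 2 the chloro sits on a ring of carbon only, para to a large group, while in compound 4 it sits on a ring that is part of a fused or bridged system of two rings, meta to a fused ring and para to a fused ring. Within the data shown here, from compound 3 to compound 4 a step of about a 1.7-fold higher number from compound 3 to compound 4 (0.24 log units; within the scatter) is expected in this assay, resting on the one earlier example, a 3.9-fold higher number from compound 1 to compound 2 (0.60 log units; beyond the scatter), with a wide margin because that step was made at a different place. Compound 4 is estimated at 8000 nM, between 3000 nM and 22000 nM.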

Compound 4, half-maximal inhibitory concentration: 1340 nM
Compound 4: middle estimate off by 6.0-fold (0.78 log units), on the high side, outside the stated range (below it).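

In this assay, chloro in place of fluoro on an aromatic carbon gives a 3.4-fold lower number from compound 3 to compound 4 (0.54 log units; beyond the scatter), and chloro in place of hydrogen at that same place gives a 4.4-fold lower number from compound 2 to compound 4 (0.65 log units; beyond the scatter). The halogen exchange therefore does not carry over from one core to the other as a fixed increment, and its direction is reversed between the two cases: the same change on two cores in this assay, a 3.9-fold higher number (0.60 log units; beyond the scatter) from compound 1 to compound 2 and a 3.4-fold lower number (0.54 log units; beyond the scatter) from compound 3 to compound 4, 14-fold (1.13 log units) apart, beyond the scatter of two such steps This does not show why the two steps part, since the exchanges differ both in the place of the halogen and in the rest of the molecule, and with one example of each, neither difference can be singled out and no general rule for the exchange follows.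

Still open, from the compounds shown here alone, is whether the step depends on the halogen on the other ring, which a compound with fluoro on both rings would test by completing the set of exchanges. Also open, going by these compounds, is how groups other than halogens, such as methoxy, a nitrile or an amine, would read at the place occupied by the chloro in compound 4.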